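The compounds below may be only part of what the source reports. "The series", "measured", "known", "first", "only" and "open" are said of these compounds alone.

Three compounds of the series have numbers in a functional assay for antagonist activity at corticotropin-releasing factor receptor 1 (Homo sapiens); on this read-out lower numbers stand for stronger inhibition and higher numbers for weaker inhibition. Compound 1 `CCCCN(CC)c1nc(C)nc2c1nnn2-c1c(Br)cc(OC)cc1OC` gives 3.5 nM in this assay, the lowest of the three. Compound 2 `Cc1cc(C)c(-n2c(C)c(C)c3c(-c4ccccc4C(F)(F)F)nc(C)nc32)c(C)c1` gives 9.7 nM and compound 3 `CSc1nn(-c2c(Cl)cc(Cl)cc2Cl)c2nc(C)nc(-c3ccccc3C(F)(F)F)c12` gives 33.4 nM, both beyond the scatter from compound 1, so compound 1 is the most potent of the measured set. Among the measured compounds shown here, compounds 2 and 3 each carry a 2-(trifluoromethyl)phenyl group on their cores, but their cores differ from that of compound 1, and no step between measured compounds that differ in a single place is available.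

Compound 4 `COc1cc(Br)c(-n2nnc3c(-c4ccccc4C(F)(F)F)nc(C)nc32)c(OC)c1` keeps the core of compound 1 and differs in one place: 2-(trifluoromethyl)phenyl in place of butyl(ethyl)amino on an aromatic carbon. For the measured compounds named here, the only guide is that the two measured compounds bearing a 2-(trifluoromethyl)phenyl group, compound 2 at 9.7 nM and compound 3 at 33.4 nM, sit above compound 1. A loss beyond the scatter is expected, of the size a 4.3-fold higher number from compound 1 to compound 4 (0.63 log units; beyond the scatter). For compound 4 the estimate in this assay is 15 nM, with a range from 4 nM to 60 nM.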

Compound 4, inhibition constant: 21.4 nM
Compound 4: the middle estimate sits 1.4-fold (0.15 log units) below what was measured; low and high end bracket the measured number.
By their numbers in this assay, from the lowest: compound 1; then compound 2; then compounds 4 and 3 (each within the scatter of the next).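

In this assay, among the compounds shown here, 2-(trifluoromethyl)phenyl in place of butyl(ethyl)amino on the aromatic carbon next to the ring nitrogen gives a 6.1-fold higher number from compound 1 to compound 4 (0.79 log units; beyond the scatter), the only single-place comparison so far. This position therefore accepts an aromatic ring without an amino nitrogen and keeps inhibition in the nanomolar range, although with a modest loss beyond the scatter. No measurement here accounts for the loss.

The step changes the whole substituent at once, so it cannot separate the removal of the amino nitrogen and the butyl and ethyl chains from the arrival of the aromatic ring or the trifluoromethyl group. Open too, on these data alone, is how a plain phenyl, a shorter diethylamino group or a cyclic amine such as morpholine would read at this carbon on the same core.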